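The source may report more compounds than this note shows. Statements on the series, on what has been measured and on what is new or still open speak of the compounds shown alone.

Measured in this series:
- compound 1 `CC(=O)OCc1ccc2oc(=O)c(C(=O)Sc3ccccc3)cc2c1` — 73.8%
- compound 2 `CC(=O)OCc1ccc2oc(=O)c(C(=O)Nc3cccc(Cl)c3)cc2c1` — 42.8%
- compound 3 `CCCCC(=O)OCc1ccc2oc(=O)c(C(=O)Oc3cccc(Br)c3)cc2c1` — 32.3%

In a functional assay on HT-1080 cells (Homo sapiens), read by transwell migration, with a stated time of 24 h, tested at 10 uM (a lower number here means a stronger effect, a higher number a weaker effect of the compound at the concentration tested), compound 3 stands lowest of the three numbers. Its nearest neighbour is compound 2, and that gap is beyond the scatter; the gap to compound 1 is wider still and also beyond the scatter. Going by the values given here, the single step measured between compounds differing in one place, a number 31 percentage points lower from compound 1 to compound 2 (beyond the scatter), concerns the group carried on the other carbonyl carbon of the shared core and is large. Among the compounds with values here, it does not touch the ester chain that changes in the step considered here, and no measured pair speaks to that chain at all.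

Compound 4 `CC(C)(C)C(=O)OCc1ccc2oc(=O)c(C(=O)Oc3cccc(Br)c3)cc2c1` is to be measured in this assay. It differs from compound 3 by tert-butyl in place of butyl on a carbonyl carbon: the leaving and entering groups have the same atom count, no ring, and no hydrogen-bond donors or acceptors. Within the data shown here, with no measured step bearing on this change, and nothing suggesting a large shift from it, the step from compound 3 to compound 4 is expected to be a number 2.7 percentage points higher from compound 3 to compound 4 (within the scatter), that is, none beyond the scatter. Compound 4 is therefore estimated to give 35% in this assay, with a range from 20% to 52%.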

Compound 4, a percentage reported as activity, at one concentration (the size of the read-out at that concentration, not a potency): 23.6%
Beside the measured number, compound 4's estimate is 11.4 percentage points above it; the range from low to high includes it.
By their numbers in this assay, from the lowest: compounds 4 and 3 (each within the scatter of the next); then compound 2; then compound 1.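

Going by these compounds alone, these notes give the first reading on the ester chain: in this assay, the step on a carbonyl carbon whose other neighbours are oxygen next to a carbonyl group is a number 8.7 percentage points lower from compound 3 to compound 4 (within the scatter). Butyl and tert-butyl carry the same heavy-atom count and differ only in how those carbons are joined, and here compound 3 and compound 4 stay within the scatter of each other, so this pair gives no separation between the two chains. Nothing available accounts for this outcome or bears on it.

The reading covers only these two chains on a single core with the bromophenyl ester, and compound 1 and compound 2, which carry the acetyl ester, differ from compound 3 in more than one place, so the shorter chain cannot be judged against butyl. Still open, on these data alone, is whether a longer chain such as octyl, a benzoyl group, or a chain ending in an amine or a carboxylic acid at this place would move the number beyond the scatter, and whether the tert-butyl result would hold with the anilide group of compound 2 on the other carbonyl carbon.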